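The source may report more compounds than this note shows. Statements on the series, on what has been measured and on what is new or still open speak of the compounds shown alone.

Compound 1 `Cc1cc(NC(=O)Nc2cccc([N+](=O)[O-])c2)c2ccccc2n1`: > 25000 nM
Compound 2 `Cc1cc(NC(=O)Nc2cccc(C(N)=O)c2)c2ccccc2n1`: > 25000 nM
Compound 3 `Cc1cc(NC(=O)Nc2cccc(F)c2)c2ccccc2n1`: > 25000 nM

In an ADME assay on BJ cells (Homo sapiens) for cytotoxicity, with a stated time of 72 h (a higher number here means that more compound is needed for the effect, a lower number that less compound is needed), compound 3 gives > 25000 nM, which is a limit and not a number. It has no position of its own among the three measured compounds, since what they share is the limit of > 25000 nM in this assay, at which 3 of the 3 values shown sit.

Compound 4 `COC(=O)c1cccc(NC(=O)Nc2cc(C)nc3ccccc23)c1` differs from compound 3 in one place, with methoxycarbonyl in place of fluoro on an aromatic carbon, meta to a large group (methoxycarbonyl in place of fluoro on an aromatic carbon). The group that leaves and the group that enters have been compared only indirectly. The closest guidance comes from the swaps among nitro, carbamoyl and fluoro on an aromatic carbon, yet none of these gives a size: a step that the two limits leave unreadable from compound 1 to compound 2, a step that the two limits leave unreadable from compound 1 to compound 3 and a step that the two limits leave unreadable from compound 2 to compound 3.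

So the data show no substitution that moves the result in this assay away from the limit, and no direction can be drawn from them. The expectation therefore rests on (the limit of > 25000 nM in this assay, at which 3 of the 3 values shown sit), and compound 4 will most likely be reported as a limit too. The estimated step is a number no higher from compound 3 to compound 4 (the limit leaves the size open), so no change beyond the usual scatter is expected. For compound 4 the estimated value is 25000 nM, with an expected range of 12000 nM to 50000 nM.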

Compound 4, half-maximal effective concentration: 21000 nM
The estimate for compound 4 lay 1.2-fold (0.08 log units) above the measured number; the measured number falls inside the stated range.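

In this assay, going by these compounds alone, compound 4, with methoxycarbonyl on an aromatic carbon meta to a large group, gives 21000 nM, the first readable number in the set rather than a limit, so a change at this position can bring the result within the range the assay can read. On these data alone, measured against the fluoro, nitro and carbamoyl compounds, the change is an at least 1.1-fold lower number from compound 3 to compound 4 (0.07 log units; that floor lies within the scatter), an at least 1.1-fold lower number from compound 1 to compound 4 (0.07 log units; that floor lies within the scatter) and an at least 1.1-fold lower number from compound 2 to compound 4 (0.07 log units; that floor lies within the scatter); each of these is only a floor within the scatter, so the true size of the steps stays unknown and no real shift can be claimed. The set as a whole is still dominated by a limit, which is not a number: the limit of > 25000 nM in this assay, at which 3 of the 4 values shown sit.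

The compounds shown leave open whether any group at this aromatic carbon can bring the value clearly below that limit, for example an amine, a carboxylic acid or a longer chain such as ethoxycarbonyl. They also leave open whether a value such as that of compound 4 depends on the methoxy on the carbonyl carbon or would survive a change elsewhere on the shared core.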